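Moving the amino group on the pyridine of compound 2

The source may report more compounds than this note shows. Statements on the series, on what has been measured and on what is new or still open speak of the compounds shown alone.

Compound 2 `CCCc1nc(-c2cccc(N)n2)c(-c2ccccc2C)s1` was tested in a functional assay on the whole organism (stomach) with Rattus norvegicus as the target, at a dose of 10 umol/kg by the intravenous route (on this read-out higher numbers stand for more inhibition at the one dose given (going by the name of the read-out) and lower numbers for less inhibition), where compound 2 gives 48%. Compound 1 `Cc1ccccc1-c1sc(Cc2ccccc2)nc1-c1ccccn1` gives 29%, a number beyond the scatter below that of compound 2, while compound 3 `CCCc1nc(-c2cccc(NC)n2)c(-c2ccccc2C)s1` gives 42%, which lies within the scatter of compound 2. Compound 4 `CCCc1nc(-c2cc(N)ccn2)c(-c2ccccc2C)s1` has not been measured in this assay. The change from compound 2 to compound 4 is 4-aminopyridin-2-yl in place of 6-aminopyridin-2-yl on an aromatic carbon. Among the measured compounds shown here, the only measured step that touches the same ring is a number 6 percentage points lower from compound 2 to compound 3 (within the scatter), where a methyl is added on the amine nitrogen; no measured pair shows the amino group moved to another ring carbon. On this basis the step is expected to stay small, and compound 4 is estimated at 40% with a range from 25% to 55%. For the measured compounds named here, the expected step of a number 8 percentage points lower from compound 2 to compound 4 (within the scatter) is thus within the scatter, but the range is wide since no step of this kind has been measured.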

Compound 4, a percentage reported as inhibition, in the whole organism at one dose (the size of the read-out at that dose, not a potency): 36%
For compound 4 the middle estimate is 4 percentage points above the measured one, and the stated range covers the measured number.
By their numbers in this assay, from the lowest: compounds 1, 4, 3 and 2 (each within the scatter of the next, the first and the last beyond it).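

In this assay, the step of a number 12 percentage points lower from compound 2 to compound 4 (beyond the scatter) shows that the place of the amino group on the pyridine ring counts, even though the group itself stays unchanged. The earlier step on this ring, a number 6 percentage points lower from compound 2 to compound 3 (within the scatter), altered the amine nitrogen and stayed within the scatter, whereas this shift of the same group goes beyond it, though only modestly. The 6-aminopyridin-2-yl and 4-aminopyridin-2-yl groups have the same heavy atoms, donors and acceptors, so those counts do not separate them, and no evidence at hand bears on the origin of the step.

As far as these compounds go, it remains open whether a methyl on the amine nitrogen of compound 4 would again leave the number within the scatter. Also open, from the compounds shown here alone, is what a hydroxyl or methoxy group would give in place of the amino group on either ring.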